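A Methylthiophene in Place of an Indole

The compounds below may be only part of what the source reports. "The series", "measured", "known", "first", "only" and "open" are said of these compounds alone.

In a toxicity assay on MT4 cells (Homo sapiens) for cytotoxicity, read by MTT assay, with a stated time of 5 days (a higher number here means that more compound is tolerated, a lower number that less compound is tolerated), compound 2 `Cc1cc(-c2ccc3cc[nH]c3c2)cc(C)c1Nc1ccnc(Nc2ccc(C#N)cc2)n1` gives 5800 nM, the higher of two measured numbers, while compound 1 `Cc1cc(-c2ccco2)cc(C)c1Nc1ccnc(Nc2ccc(C#N)cc2)n1` gives 1700 nM. Compound 3 `Cc1ccc(-c2cc(C)c(Nc3ccnc(Nc4ccc(C#N)cc4)n3)c(C)c2)s1` follows from compound 2 by one change, 5-methylthiophen-2-yl in place of 1H-indol-6-yl on an aromatic carbon. Among the compounds with values here, one measured step bears on this, a modest one, for 1H-indol-6-yl in place of furan-2-yl: a 3.4-fold higher number from compound 1 to compound 2 (0.53 log units; beyond the scatter). Since the entering group, like furan-2-yl, is a five-membered aromatic ring with 1 hetero atom, a partial reversal toward a lower number is expected in this assay. The expected change is a 2.2-fold lower number from compound 2 to compound 3 (0.35 log units; beyond the scatter). Compound 3 is estimated at 2600 nM, within an expected range of 1000 nM to 7000 nM.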

Compound 3, half-maximal cytotoxic concentration: 28000 nM
For compound 3 the middle estimate is 11-fold (1.03 log units) below the measured one; measured number outside the range, above it.
By their numbers in this assay, from the lowest: compound 1; then compound 2; then compound 3.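

In this assay, a five-membered aromatic ring with 1 hetero atom did not bring the number down: replacing 1H-indol-6-yl with 5-methylthiophen-2-yl gave a rise (a 4.8-fold higher number from compound 2 to compound 3 (0.68 log units; beyond the scatter)). Two groups of that same ring type also stand far apart (a 16-fold higher number from compound 1 to compound 3 (1.22 log units; beyond the scatter)), so at this carbon the ring type alone does not set the number. Nothing available explains this difference. The compounds shown leave open whether the methyl group of 5-methylthiophen-2-yl or its sulfur carries the rise, and how an amine or a carboxylic acid would fare at this carbon.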